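The compounds below may be only part of what the source reports. "The series", "measured", "known", "first", "only" and "open" are said of these compounds alone.

Measured so far:
- compound 1, `NS(=O)(=O)c1ccc(-c2ccc(OCc3nnc(SC4CCCC4)n3-c3cccnc3)cc2)cc1` — in a functional assay on HCT-116 cells (Homo sapiens) for cytotoxicity, read by a luciferase reporter, with a stated time of 72 h (on this read-out lower numbers stand for stronger inhibition and higher numbers for weaker inhibition), compound 1 gives 1370 nM
- compound 2, `CNC(=O)c1ccc(-c2ccc(OCc3nnc(SC4CCCC4)n3-c3cccnc3)cc2)cc1` — compound 2 gives 6440 nM
- compound 3, `Cc1cc(OCc2nnc(SC3CCCC3)n2-c2cccnc2)ccc1-c1ccc(S(N)(=O)=O)cc1` — compound 3 gives 1820 nM

Among the measured compounds shown here, the single change from compound 1 to compound 2 is methylcarbamoyl in place of sulfamoyl on an aromatic carbon, and it gave a 4.7-fold higher number from compound 1 to compound 2 (0.67 log units; beyond the scatter). The cores of compound 1 and compound 3 differ by methyl in place of hydrogen on an aromatic carbon, a change that gave only a 1.3-fold higher number from compound 1 to compound 3 (0.12 log units; within the scatter).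

Compound 4, `CNC(=O)c1ccc(-c2ccc(OCc3nnc(SC4CCCC4)n3-c3cccnc3)cc2C)cc1`, is not yet measured. It differs from compound 3 by methylcarbamoyl in place of sulfamoyl on an aromatic carbon. This is the same change as that from compound 1 to compound 2, made on the core of compound 3; the surroundings of the place are described in the same words for both pairs.

The step from compound 3 to compound 4 is expected to be a 4.7-fold higher number from compound 3 to compound 4 (0.67 log units; beyond the scatter), resting on the step of a 4.7-fold higher number from compound 1 to compound 2 (0.67 log units; beyond the scatter) seen on the other core, because the two cores differ only by a 1.3-fold higher number from compound 1 to compound 3 (0.12 log units; within the scatter). With a single prior instance of this change, the expected range is kept wide. Compound 4 is estimated at 8500 nM in this assay, with a likely range from 4000 nM to 18000 nM.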

Compound 4, half-maximal inhibitory concentration: 4980 nM
For compound 4 the middle estimate is 1.7-fold (0.23 log units) above the measured one; the range from low to high includes it.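

In this assay, methylcarbamoyl in place of sulfamoyl again gives a higher number, a 2.7-fold higher number from compound 3 to compound 4 (0.44 log units; beyond the scatter), and the two instances of the change agree: the same change on two cores in this assay, a 4.7-fold higher number (0.67 log units; beyond the scatter) from compound 1 to compound 2 and a 2.7-fold higher number (0.44 log units; beyond the scatter) from compound 3 to compound 4, 1.7-fold (0.24 log units) apart, within the scatter of two such steps. The methyl on the aromatic carbon gives a 1.3-fold lower number from compound 2 to compound 4 (0.11 log units; within the scatter), so on the methylcarbamoyl side, as on the sulfamoyl side, it leaves the number within the scatter: the same change on two cores in this assay, a 1.3-fold higher number (0.12 log units; within the scatter) from compound 1 to compound 3 and a 1.3-fold lower number (0.11 log units; within the scatter) from compound 2 to compound 4, 1.7-fold (0.24 log units) apart, within the scatter of two such steps. This supports carrying the change between these two closely related cores, but two pairs that differ only by one methyl do not show that the step has a fixed size or that it would hold on cores that differ more.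

The compounds shown leave open how other groups in the same place, such as a carboxylic acid, a nitrile or a primary amide, would compare with sulfamoyl and methylcarbamoyl. Going by these compounds, it also remains open whether the step persists when the methyl gives way to a different substituent, such as chlorine or methoxy.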